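A few compounds are considered here, and "the series" means these few. Any claim that something is new, unique, unknown or untested is made for them only; others in the source may bear on it.

Compound 3 `CC/C(=C(/c1ccc(/C=C/C(=O)O)cc1)c1cc2ccccc2[nH]1)c1ccccc1C(F)(F)F` gives the lowest number of the three measured in a functional assay on MCF7 cells (Homo sapiens) for inhibition (on this read-out lower numbers stand for stronger inhibition and higher numbers for weaker inhibition), at 8 nM. Compound 1 `CC/C(=C(/c1ccc(/C=C/C(=O)O)cc1)c1cc2ccccc2[nH]1)c1ccccc1`, the unsubstituted parent, gives 108 nM in this assay, and compound 2 `CC/C(=C(/c1ccc(/C=C/C(=O)O)cc1)c1cc2ccccc2[nH]1)c1ccccc1C`, with a methyl in place of hydrogen, gives 33 nM. The steps within the set are a 3.3-fold lower number from compound 1 to compound 2 (0.51 log units; beyond the scatter), a 14-fold lower number from compound 1 to compound 3 (1.13 log units; beyond the scatter) and a 4.1-fold lower number from compound 2 to compound 3 (0.62 log units; beyond the scatter), so each change at this aromatic carbon so far has lowered the number, and trifluoromethyl has done so most.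

Compound 4 `CC/C(=C(/c1ccc(/C=C/C(=O)O)cc1)c1cc2ccccc2[nH]1)c1ccccc1OC(F)(F)F` differs from compound 3 by trifluoromethoxy in place of trifluoromethyl on an aromatic carbon. Within the data shown here, no measured step in this assay covers trifluoromethoxy, so the three steps bear on it only by showing that substitution at this carbon has been well tolerated and rewarded. A change from trifluoromethyl to trifluoromethoxy is expected to give a step of a 1.3-fold higher number from compound 3 to compound 4 (0.10 log units; within the scatter), that is, no change clearly beyond the scatter in either direction. Compound 4 is therefore estimated at 10 nM, with a likely range from 4 nM to 30 nM.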

Compound 4, half-maximal inhibitory concentration: 206 nM
Compound 4: the middle estimate sits 21-fold (1.31 log units) below what was measured; measured number outside the range, above it.
By their numbers in this assay, from the lowest: compound 3; then compound 2; then compounds 1 and 4 (each within the scatter of the next).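

In this assay the earlier reward for substitution at this aromatic carbon turns out not to hold for every group: trifluoromethoxy in place of trifluoromethyl brings a 26-fold higher number from compound 3 to compound 4 (1.41 log units; beyond the scatter) and so shows that these two fluorinated groups, which differ by one oxygen, are not interchangeable here. Trifluoromethoxy in place of methyl brings a 6.2-fold higher number from compound 2 to compound 4 (0.80 log units; beyond the scatter) and trifluoromethoxy in place of hydrogen brings a 1.9-fold higher number from compound 1 to compound 4 (0.28 log units; within the scatter) and so compound 4 does not continue the lower numbers of compound 2 and compound 3, and it cannot be told apart from the unsubstituted parent. Nothing available explains this gap between the two groups.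

As far as these compounds go, it remains open whether the higher number goes with the oxygen or with the fluorines on it, which a methoxy group or an ethyl group at this carbon would help to separate. From the compounds shown here alone, how a chlorine or a nitrile would read at this carbon also remains open.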